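This account rests on a few compounds, and the source may have more. Where it says the series, first, only, none or still open, it means among the compounds named here.

Working notes on a small series built on a shared core. Compound 1 `CC(Sc1nc2c(cnn2C)c(=O)n1-c1ccc(CCO)cc1)c1ccccc1` has been measured in an assay on isolated protein for inhibition of Retinaldehyde dehydrogenase 3 (Homo sapiens) (a higher number here means a weaker inhibitor, a lower number a stronger inhibitor), where compound 1 gives 3000 nM. Compound 2 `Cn1ncc2c(=O)n(-c3ccccc3)c(SC(C)(C)c3ccccc3)nc21` has also been run, and in this assay compound 2 gives 1390 nM. Of the two numbers in hand, that of compound 1 is the higher, and the gap to compound 2 lies beyond the scatter. Compound 1 and compound 2 differ in more than one place, so their two values say nothing about any single change; they stand only as the two values they are.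

Compound 3 `CC(Sc1nc2c(cnn2C)c(=O)n1-c1ccc(C#N)cc1)c1ccccc1` has not yet been measured in this assay. It differs from compound 1 in one place: cyano in place of 2-hydroxyethyl on an aromatic carbon. Seen one bond further out, the aryl on the core goes from 4-(2-hydroxyethyl)phenyl to 4-cyanophenyl.

Among the compounds with values here, no pair of measured compounds differing in one place is available, so no measured step anchors this change. The expectation for the step from compound 1 to compound 3 is a change of at most modest size, more likely towards a lower number than a higher one, and possibly none beyond the scatter, as a 1.4-fold lower number from compound 1 to compound 3 (0.13 log units; within the scatter) expresses. Compound 3 is therefore estimated at 2200 nM in this assay, with a range from 700 nM to 7000 nM.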

Compound 3, half-maximal inhibitory concentration: 200 nM
Compound 3: middle estimate off by 11-fold (1.04 log units), on the high side, and the stated range ends above it.
By their numbers in this assay, from the lowest: compound 3; then compound 2; then compound 1.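

This position on the shared core is clearly sensitive to what it carries. In this assay, within the data shown here, cyano in place of 2-hydroxyethyl on the aromatic carbon para to a large group gives a 15-fold lower number from compound 1 to compound 3 (1.18 log units; beyond the scatter), a large step and the first change that can be read at a single place. The 2-hydroxyethyl that leaves carries a hydrogen-bond donor and the cyano that enters carries none, but this one pair cannot show whether that difference matters, and no measurement at hand bears on why the number falls so far.

On these data alone, it remains open whether the step reflects something cyano brings or only the removal of 2-hydroxyethyl, a question that a plain hydrogen, a methoxy group, a primary amide or a hydroxymethyl group at the same position would help to separate, since compound 2 has an unsubstituted phenyl but differs from compound 1 in more than one place. Also open, as far as these compounds go, is whether the same change would give a step of similar size on the other sulfur substituent of compound 2, or with a carboxylic acid or an amine in the same place.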